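The compounds below may be only part of what the source reports. "The series", "measured", "known", "first", "only" and "open" are said of these compounds alone.

Compound 1 `C=CC(=O)Nc1cccc(Nc2nc(N)nc(Nc3ccc(Oc4ccccc4)cc3)n2)c1` is the single measured anchor here: in a functional assay on Ramos cells (Homo sapiens) for antiproliferative activity, read by CCK-8 assay, with a stated time of 24 h (on this read-out lower numbers stand for stronger inhibition and higher numbers for weaker inhibition), compound 1 gives 20000 nM. Among the measured compounds shown here, compound 2 `C=CC(=O)Nc1cccc(Nc2ncnc(Nc3ccc(C(=O)Nc4ccccn4)cc3)n2)c1` shares much of its build, but in this assay compound 2 gives "not determined" (no result reported), so no measured step can be drawn from it. Compound 3 `C=CC(=O)Nc1cccc(Nc2ncnc(Nc3ccc(C(=O)Nc4ccc(C)cn4)cc3)n2)c1` differs from compound 2 in one place only: methyl in place of hydrogen on an aromatic carbon. With nothing measured on either side of that change, the expectation is a step no larger than the usual scatter of this assay, in no particular direction. Compound 3 is accordingly estimated at 10000 nM, within 2000 nM to 50000 nM.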

Compound 3, half-maximal inhibitory concentration: > 100000 nM
Compound 3 ended at the assay's limit; the forecaster's own chance of this, stated with the estimate: 30%; at least 10-fold (1.00 log units) between middle value and limit.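

No step can be read from compound 2 to compound 3: compound 2 has no reported result, and the value for compound 3 is a limit, not a number. On these data alone, whether 5-methylpyridin-2-yl changes activity relative to pyridin-2-yl stays open.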